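This account rests on a few compounds, and the source may have more. Where it says the series, first, only, none or still open, it means among the compounds named here.

Compound 2 `N=c1sc2cc(OC(F)(F)F)ccc2n1CCS(=O)(=O)O` shares its core with compound 1 `N=c1sc2cc(OC(F)(F)F)ccc2n1CC(N)=O`. In a functional assay on the whole organism with Rattus norvegicus as the target (a lower number here means that less compound is needed, a higher number that more compound is needed for the effect), compound 1 gives 7 mg/kg. Compound 2, measured in this assay, gives > 10 mg/kg, which is a limit of the assay and not a number, so compound 2 sits at the limit of > 10 mg/kg in this assay, at which 1 of the 2 values shown sits. Among the measured compounds shown here, the single measured step, an at least 1.4-fold higher number from compound 1 to compound 2 (0.15 log units; that floor lies within the scatter), is therefore bounded from one side only, and its floor falls inside the scatter; the swap of carbamoyl for sulfo on a saturated chain carbon bound to an aromatic nitrogen did not lower the dose. Compound 3 `CCCSCCn1c(=N)sc2cc(OC(F)(F)F)ccc21` differs from compound 2 in one place: propylsulfanyl in place of sulfo on a saturated chain carbon, two bonds along the chain from an aromatic nitrogen. For the measured compounds named here, no measured step covers this change directly; the step from compound 1 to compound 2 is the only comparison, and it reaches compound 2 without a fixed value. The account expects compound 3 to move back toward the region of compound 1 rather than remain at the limit, with an expected downward step of an at least 1.2-fold lower number from compound 2 to compound 3 (0.09 log units; that floor lies within the scatter), its size left open by the one-sided bound. Compound 3 is estimated at 8 mg/kg, within a range from 3 mg/kg to 20 mg/kg.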

Compound 3, dose for half-maximal effect: 2.4 mg/kg
Beside the measured number, compound 3's estimate is 3.3-fold (0.52 log units) above it; the whole stated range lies above it.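

Where the step from compound 1 to compound 2 had a floor inside the scatter, this position now gives a step beyond it: with propylsulfanyl in place of sulfo on a saturated chain carbon, two bonds along the chain from an aromatic nitrogen, this assay records an at least 4.1-fold lower number from compound 2 to compound 3 (0.61 log units; beyond the scatter). Compound 2 stands at a limit of the assay and not at a number, so this step is bounded from one side only: the limit of > 10 mg/kg in this assay, at which 1 of the 3 values shown sits. The change also does more than regain the level of the carbamoyl compound, and the same read-out gives a 2.9-fold lower number from compound 1 to compound 3 (0.46 log units; beyond the scatter), the first step among these compounds with both ends fixed and beyond the scatter.

The compounds shown leave open which part of propylsulfanyl goes with the lower dose, as the sulfur and the propyl chain enter together and only a group such as propoxy or butyl at the same place would part them. They also leave open whether a longer chain, or an amine at the chain end, would lower the dose further or raise it again.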